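Trifluoromethyl for chloro: compound 3 to compound 4

A few compounds are considered here, and "the series" means these few. Any claim that something is new, unique, unknown or untested is made for them only; others in the source may bear on it.

Compound 1 `N#Cc1cccc([C@]23CCC(N(CCN4CCCC(O)C4)C(=O)Nc4ccc(F)c(Cl)c4)CC2C3)c1` gives 22 nM in a functional assay for antagonist activity at melanin-concentrating hormone receptor 1 (Homo sapiens); a higher number here means a weaker inhibitor, a lower number a stronger inhibitor. Compound 2 `CC(=O)N1CCC(CN(C(=O)Nc2ccc(F)c(Cl)c2)C2CC[C@]3(c4cccc(C#N)c4)CC3C2)CC1` gives 312 nM in this assay, and compound 3 `CS(=O)(=O)N1CCC(CN(C(=O)Nc2ccc(F)c(Cl)c2)C2CC[C@]3(c4cccc(C#N)c4)CC3C2)CC1` gives 7.19 nM, the lowest number of the three, with a 3.1-fold lower number from compound 1 to compound 3 (0.49 log units; beyond the scatter) and a 43-fold lower number from compound 2 to compound 3 (1.64 log units; beyond the scatter). Those steps, with a 14-fold higher number from compound 1 to compound 2 (1.15 log units; beyond the scatter), all concern the substituent on the amide-type nitrogen; none alters the aryl amine.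

Compound 4 `CS(=O)(=O)N1CCC(CN(C(=O)Nc2ccc(F)c(C(F)(F)F)c2)C2CC[C@]3(c4cccc(C#N)c4)CC3C2)CC1` differs from compound 3 only there: trifluoromethyl in place of chloro on an aromatic carbon. Among the measured compounds shown here, no measured step bears on this position, so no step beyond the scatter is expected, in either direction. Compound 4 is estimated at 8 nM in this assay, with a range of 3 nM to 25 nM, which means an expected 1.1-fold higher number from compound 3 to compound 4 (0.05 log units; within the scatter).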

Compound 4, inhibition constant: 26 nM
Estimate against measurement, compound 4: 3.3-fold (0.51 log units) below, outside the stated range (above it).
By their numbers in this assay, from the lowest: compound 3; then compounds 1 and 4 (each within the scatter of the next); then compound 2.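

Trifluoromethyl in place of chloro on the 3-chloro-4-fluorophenyl group gives the first measured step at this position in this assay (a 3.6-fold higher number from compound 3 to compound 4 (0.56 log units; beyond the scatter)). The aryl amine is therefore not a silent site: the change registers beyond the scatter, though only as a modest step. Compound 3 remains the better of the pair, with the 1-(methylsulfonyl)piperidin-4-yl group held constant.

Open, on these data alone, is whether a bromo or methoxy group here would track chloro or trifluoromethyl, and whether the step carries over to the (3-hydroxypiperidin-1-yl)methyl or 1-acetylpiperidin-4-yl compounds. No supporting measurement bears on this result.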